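This account rests on a few compounds, and the source may have more. Where it says the series, first, only, none or still open, it means among the compounds named here.

Compound 1 `CC(C)(O/N=C(\C(=O)N[C@@H]1C(=O)N(S(=O)(=O)O)[C@@H]1CN1CCC1=O)c1csc(N)n1)C(=O)O` carries a 2-oxoazetidin-1-yl group on the shared core. In a physicochemical assay for metabolic stability, read by HPLC and mass spectrometry, in phosphate buffer, at 37 degrees C, at pH 7.4 (on this read-out lower numbers stand for a shorter-lived compound and higher numbers for a longer-lived compound), compound 1 gives only the limit > 1000 h, so its standing among the numbers shown is known only as a limit, not a value. Compound 2 `CC(C)(O/N=C(\C(=O)N[C@@H]1C(=O)N(S(=O)(=O)O)[C@@H]1CN1CCNC1=O)c1csc(N)n1)C(=O)O` likewise gives only the limit > 1000 h in this assay. Compound 3 `CC(C)(O/N=C(\C(=O)N[C@@H]1C(=O)N(S(=O)(=O)O)[C@@H]1Cn1cncn1)c1csc(N)n1)C(=O)O` gives 233 h in this assay. Among the compounds with values here, two measured steps bear on the change at hand: an at least 4.2-fold lower number from compound 1 to compound 3 (0.63 log units; beyond the scatter) and an at least 4.2-fold lower number from compound 2 to compound 3 (0.63 log units; beyond the scatter); the step that the two limits leave unreadable from compound 1 to compound 2 cannot be read because of the limit of > 1000 h in this assay, at which 2 of the 3 values shown sit. Compound 4 `CC(C)(O/N=C(\C(=O)N[C@@H]1C(=O)N(S(=O)(=O)O)[C@@H]1Cn1cc(CO)nn1)c1csc(N)n1)C(=O)O` differs from compound 1 as 4-(hydroxymethyl)-1H-1,2,3-triazol-1-yl in place of 2-oxoazetidin-1-yl on a saturated chain carbon bound to a saturated ring carbon; a triazolyl ring enters again. Compound 4 is therefore expected to give 250 h in this assay, with a range of 100 h to 700 h, an estimated step of an at least 4.0-fold lower number from compound 1 to compound 4 (0.60 log units; beyond the scatter).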

Compound 4, half-life: > 37 h
Compound 4: only a limit was reported; the forecaster's own chance of this, stated with the estimate: 15%; the middle value is on the limit's open side.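

In this assay, within the data shown here, compound 4 gives only a limit, > 37 h, so no step from compound 1, compound 2 or compound 3 to compound 4 can be read. Still open, going by these compounds, is whether compound 4 outlasts compound 3.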